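Trimming the Side Chain of a Succinimide Amide

This account rests on a few compounds, and the source may have more. Where it says the series, first, only, none or still open, it means among the compounds named here.

Measured compounds:
- Compound 1, `COCC(C(=O)N1CCN(c2cccc(C(F)(F)F)c2)CC1)N1C(=O)CCC1=O`: 75%
- Compound 2, `CC(C(=O)N1CCN(c2ccccc2C(F)(F)F)CC1)N1C(=O)CCC1=O`: 50%
- Compound 3, `CCC(C(=O)N1CCN(c2cccc(C(F)(F)F)c2)CC1)N1C(=O)CCC1=O`: 75%

In a functional assay on the whole organism (strain Swiss) with Mus musculus as the target, with a stated time of 2 h, at a dose of 300 mg/kg (on this read-out higher numbers stand for a stronger effect at the one dose given and lower numbers for a weaker effect), compound 3 gives 75%. On this read-out compound 3 stands level with compound 1, and the two together are the highest of the three numbers; compound 2 sits a good deal lower, beyond the scatter.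

The next compound is compound 4, `CC(C(=O)N1CCN(c2cccc(C(F)(F)F)c2)CC1)N1C(=O)CCC1=O`. Its change from compound 3 is hydrogen in place of methyl on a saturated chain carbon, two bonds along the chain from an amide-type nitrogen in a ring and a carbonyl carbon.

Among the compounds with values here, only one measured step touches this chain: no change at the digits printed from compound 1 to compound 3 (within the scatter). Swapping methoxy for methyl at that carbon moved nothing, which suggests the chain tolerates variation. Compound 2 carries the same methyl chain as compound 4 but differs elsewhere in its structure, so its value can only be noted, not compared as a step. The expected step of a number 5 percentage points lower from compound 3 to compound 4 (within the scatter) is therefore small or none beyond the scatter. Compound 4 is estimated at 70% in this assay, with a range from 50% to 85%.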

Compound 4, a percentage reported as activity, at one dose (the size of the read-out at that dose, not a potency): 100%
The estimate for compound 4 lay 30 percentage points below the measured number, outside the stated range (above it).
By their numbers in this assay, from the lowest: compound 2; then compounds 1 and 3 (each within the scatter of the next); then compound 4.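

In this assay the number comes out a number 25 percentage points higher from compound 3 to compound 4 (beyond the scatter) and a number 25 percentage points higher from compound 1 to compound 4 (beyond the scatter) when the side chain is cut back to methyl, so this position does respond to what it carries. The earlier step between compound 1 and compound 3 showed only that ethyl and the methoxy-bearing chain read alike, and that level result hid the gain seen with the shorter methyl chain. Nothing measured here explains why the shorter chain gives the higher number.

The compounds shown leave open how the read-out would respond to an amine or a propyl chain at this position, or to a chain trimmed further so that only hydrogen remains. With a single dose on record, they also leave open whether compound 4 would keep its lead at other doses.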